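The source may hold more compounds than are shown below. What is called first, only, known or untested is meant among the compounds shown, and "the series" means these compounds.

Measured so far in a functional assay with Homo sapiens as the target; a lower number here means a stronger inhibitor, a higher number a weaker inhibitor:

Compound 1 `CC(C)[C@H](NC(=O)COc1cccc2ccccc12)C(=O)N[C@@H](CC(=O)O)C(=O)COc1ccc(C(F)(F)F)cc1` gives 12300 nM
Compound 2 `CC(C)[C@H](NC(=O)COc1cccc2ccccc12)C(=O)N[C@@H](CC(=O)O)C(=O)COc1ccc(F)cc1` gives 14300 nM
Compound 3 `CC(C)[C@H](NC(=O)COc1cccc2ccccc12)C(=O)N[C@@H](CC(=O)O)C(=O)COc1ccc(F)c(F)c1F` gives 20600 nM

Compound 3 holds the highest of the three numbers, yet it stands within the scatter of both others. The two steps that reach it are a 1.4-fold higher number from compound 2 to compound 3 (0.16 log units; within the scatter) and a 1.7-fold higher number from compound 1 to compound 3 (0.22 log units; within the scatter).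

Compound 4 `CC(C)[C@H](NC(=O)COc1cccc2ccccc12)C(=O)N[C@@H](CC(=O)O)C(=O)COc1ccc([N+](=O)[O-])cc1F` keeps the shared core and differs from compound 3 only in the aryl group, with 2-fluoro-4-nitrophenyl in place of 2,3,4-trifluorophenyl on an oxygen on a saturated carbon.

All three measured steps change this same group. The third is a 1.2-fold higher number from compound 1 to compound 2 (0.07 log units; within the scatter), and none of the three goes beyond the scatter. Going by the values given here, no measured compound carries the nitro group, so these steps bear on the change only indirectly. On this evidence, no step beyond the scatter is expected in this assay. The expected step is a 1.5-fold lower number from compound 3 to compound 4 (0.17 log units; within the scatter). Compound 4 is estimated at 14000 nM, with an expected range from 6500 nM to 30000 nM.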

Compound 4, half-maximal inhibitory concentration: 15800 nM
Compound 4: middle estimate off by 1.1-fold (0.05 log units), on the low side; the range from low to high includes it.
By their numbers in this assay, from the lowest: compounds 1, 2, 4 and 3 (each within the scatter of the next).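

In this assay, going by these compounds alone, the nitro group appears for the first time, and it makes no difference that the data can resolve: there is a 1.3-fold lower number from compound 3 to compound 4 (0.12 log units; within the scatter) and there is a 1.1-fold higher number from compound 2 to compound 4 (0.04 log units; within the scatter) as well as a 1.3-fold higher number from compound 1 to compound 4 (0.11 log units; within the scatter) in this account. Each of these steps stays within the scatter, so at this position, on an oxygen on a saturated carbon, 2-fluoro-4-nitrophenyl cannot be told apart from the three other aryl groups, although it brings hydrogen-bond acceptors that 2,3,4-trifluorophenyl lacks. Nothing available here accounts for this lack of separation.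

Still open, as far as these compounds go, is whether an amine or a carboxylic acid on the ring would give a step beyond the scatter. From the compounds shown here alone, it is also open whether a saturated alkyl chain in place of the aryl group would leave the number where it stands.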